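A Larger Ring on the Amine Side Chain

The source may hold more compounds than are shown below. What is called first, only, known or untested is meant among the compounds shown, and "the series" means these compounds.

compound 1 `CC(C)OC(=O)N1CCC(O[C@H]2CC[C@H](Oc3cnc(S(C)(=O)=O)cn3)CC2)CC1` — 119 nM
compound 2 `CS(=O)(=O)c1cnc(O[C@H]2CC[C@H](OC3CCN(CC4(C(F)(F)F)CC4)CC3)CC2)cn1` — 163 nM

In a functional assay on isolated protein for agonist activity at Glucose-dependent insulinotropic receptor (Rattus norvegicus), read by HTRF and cAMP accumulation (on this read-out lower numbers stand for an effect already at smaller amounts and higher numbers for an effect only at larger amounts of compound), compound 1 gives 119 nM and compound 2 gives 163 nM. For the measured compounds named here, compound 2 holds the higher of the two numbers, yet the only step, a 1.4-fold higher number from compound 1 to compound 2 (0.14 log units; within the scatter), lies within the scatter. Compound 3 `CS(=O)(=O)c1cnc(O[C@H]2CC[C@H](OC3CCN(CC4(C(F)(F)F)CCCC4)CC3)CC2)cn1` differs from compound 2 by a group of 9 heavy atoms (6 carbon, 3 fluorine; one five-membered non-aromatic ring of carbon only) in place of a group of 7 heavy atoms (4 carbon, 3 fluorine; one three-membered non-aromatic ring of carbon only), on a saturated chain carbon bound to an amine nitrogen in a ring. Going by the values given here, no measured step exchanges one such ring for another; the single step available concerns a different exchange at the same amine nitrogen and stayed within the scatter. Compound 3 is therefore expected to show no change beyond the scatter, a 1.0-fold higher number from compound 2 to compound 3 (0.02 log units; within the scatter). For compound 3 the estimated value is 170 nM, with a range from 60 nM to 500 nM.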

Compound 3, half-maximal effective concentration: 101 nM
Beside the measured number, compound 3's estimate is 1.7-fold (0.23 log units) above it; measured number inside the range.
By their numbers in this assay, from the lowest: compounds 3, 1 and 2 (each within the scatter of the next).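

With this assay as the read-out, the five-membered carbon ring at this place gives a 1.6-fold lower number from compound 2 to compound 3 (0.21 log units; within the scatter) and shows that the saturated chain carbon bound to an amine nitrogen in a ring carries the larger group without a change beyond the scatter. Set against the isopropoxycarbonyl group on the amine nitrogen in a ring, the same side chain gives a 1.2-fold lower number from compound 1 to compound 3 (0.07 log units; within the scatter) and also stays within the scatter. Nothing available bears on these results. On these data alone, whether a cyclohexyl ring at this place, or a methyl group instead of the trifluoromethyl, would keep the number in this range remains open.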